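The source may hold more compounds than are shown below. What is called first, only, known or untested is meant among the compounds shown, and "the series" means these compounds.

Of the compounds shown here, three built on a shared core have been measured in a physicochemical assay for lipophilicity, measured as octanol-water partition; a lower number here means a more polar compound, a higher number a more lipophilic compound. Compound 1 `O=S(=O)(c1ccccc1)N1N=C2CCCCC2C1c1ccc(Cl)cc1` gives 5.4. Compound 3 `O=S(=O)(c1ccccc1)N1N=C2CCCCC2C1c1ccc(F)cc1` differs from compound 1 in a single place: fluoro in place of chloro on an aromatic carbon. In this assay compound 3 gives 5, and the step of a number 0.40 log units lower from compound 1 to compound 3 (beyond the scatter) is modest yet lies beyond the usual scatter of repeated measurements. Compound 2 `O=S(=O)(c1cccc2ccccc12)N1N=C2CCCCC2C1c1ccc(Cl)cc1` is built on a different core; the difference between the two cores is not broken down here. In this assay compound 2 gives 6.4, the highest of the three values, and its distance from compound 1 and from compound 3 lies beyond the scatter in both cases.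

Compound 4 `O=S(=O)(c1cccc2ccccc12)N1N=C2CCCCC2C1c1ccc(F)cc1` has not yet been measured. It relates to compound 2 exactly as compound 3 relates to compound 1: fluoro in place of chloro on an aromatic carbon. The place of the change reads the same in both pairs, so this is the same change carried onto the other core. The expected step is a number 0.40 log units lower from compound 2 to compound 4 (beyond the scatter), estimated to mirror the earlier one because the identical exchange produced a number 0.40 log units lower from compound 1 to compound 3 (beyond the scatter). Compound 4 is therefore expected to give about 6 in this assay, with a likely range from 5.7 to 6.3. That expectation rests on a single prior example of the exchange, and on the assumption that the change behaves alike on both cores; the measurement will show whether it does.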

Compound 4, partition coefficient: 6
Compound 4: middle estimate and measured number agree at the digits printed; measured number inside the range.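

In this assay, fluoro in place of chloro on an aromatic carbon gives a number 0.40 log units lower from compound 2 to compound 4 (beyond the scatter) and, on the other core, a number 0.40 log units lower from compound 1 to compound 3 (beyond the scatter); the two steps are of equal size, so in these two pairs the exchange of 4-chlorophenyl to 4-fluorophenyl carries from one core to the other without any visible change in its size. Among the compounds shown here, this is only two examples of one exchange on two cores in a single kind of measurement, so it does not show that other exchanges would carry over in the same way, or that this one would do so on a third core. Nothing available here bears on why the step repeats, and the numbers alone describe the match without accounting for it.

The compounds shown carry only chloro or fluoro in this place, so it remains open whether a larger or very different group there, such as an amine, a carboxylic acid or a longer chain, would also give matching steps on the two cores. From the compounds shown here alone, it also remains open whether the same exchange would give matching steps on both cores in any other kind of measurement.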